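From methoxy to acetoxy: an untested step

A few compounds are considered here, and "the series" means these few. Any claim that something is new, unique, unknown or untested is made for them only; others in the source may bear on it.

Compound 2 `COC1CCN(c2nc(C(F)(F)F)ccc2CNC(=O)C(C)c2ccc(NS(C)(=O)=O)c(F)c2)CC1` gives 280 nM in a functional assay on CHO-K1 cells for antagonist activity at transient receptor potential cation channel subfamily V member 1 (Homo sapiens), read by FLIPR (on this read-out higher numbers stand for weaker inhibition and lower numbers for stronger inhibition), the lowest of the two numbers shown. Going by the values given here, its only neighbour, compound 1 `Cc1ccc(Nc2nc(C(F)(F)F)ccc2CNC(=O)C(C)c2ccc(NS(C)(=O)=O)c(F)c2)cc1C`, gives 1160 nM in this assay, and the step of a 4.1-fold lower number from compound 1 to compound 2 (0.62 log units; beyond the scatter) is the sole measured comparison. Compound 3 `CC(=O)OC1CCN(c2nc(C(F)(F)F)ccc2CNC(=O)C(C)c2ccc(NS(C)(=O)=O)c(F)c2)CC1` differs from compound 2 by acetyl in place of methyl on an oxygen on a saturated carbon. The measured step concerns another part of the shared core and does not bear on this exchange, so no step beyond the scatter is expected in this assay. Compound 3 is therefore expected to give 350 nM, within 120 nM to 1000 nM. The expected step is a 1.3-fold higher number from compound 2 to compound 3 (0.10 log units; within the scatter).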

Compound 3, half-maximal inhibitory concentration: 139 nM
Compound 3: middle estimate off by 2.5-fold (0.40 log units), on the high side; low and high end bracket the measured number.
By their numbers in this assay, from the lowest: compounds 3 and 2 (each within the scatter of the next); then compound 1.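

In this assay the exchange gives a 2.0-fold lower number from compound 2 to compound 3 (0.30 log units; within the scatter) and so leaves methoxy and acetoxy indistinguishable at this position, even though acetyl brings a carbonyl that methyl lacks. The comparison with the arylamino compound reads an 8.3-fold lower number from compound 1 to compound 3 (0.92 log units; beyond the scatter) and shows that the lower number seen with 4-methoxypiperidin-1-yl also holds for 4-acetoxypiperidin-1-yl. No evidence is available to explain either step. The compounds shown leave open whether a free hydroxyl, an amine or a longer ester chain on this oxygen-bearing carbon would keep the number in the same range.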